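Three Limits and a Fourth Compound Still to Be Tested

This account rests on a few compounds, and the source may have more. Where it says the series, first, only, none or still open, it means among the compounds named here.

Compound 1 `N#Cc1ccc(Nc2nc(Oc3ccnc4ccccc34)nc(N3CCCCC3)n2)cc1C(F)(F)F`: in a functional assay on DU-145 cells (Homo sapiens) for cytotoxicity, read by sulforhodamine B assay, with a stated time of 48 h (on this read-out higher numbers stand for weaker inhibition of growth and lower numbers for stronger inhibition of growth), compound 1 gives > 100000 nM, a limit of the assay rather than a number.
Compound 2 `N#Cc1ccc(Nc2nc(Oc3ccnc4ccccc34)nc(N3CCN(c4ncccn4)CC3)n2)cc1C(F)(F)F`: in this assay compound 2 gives > 100000 nM, also a limit.
Compound 3 `N#Cc1ccc(Nc2nc(Oc3ccnc4ccccc34)nc(N3CCN(c4ccccn4)CC3)n2)cc1C(F)(F)F`: in this assay compound 3 gives > 100000 nM, again a limit.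

Compound 3 therefore stands at the same limit as the two others (the limit of > 100000 nM in this assay, at which 3 of the 3 values shown sit). Compound 4 `N#Cc1ccc(Nc2nc(Oc3ccnc4ccccc34)nc(N3CCN(c4cccc(C(F)(F)F)c4)CC3)n2)cc1C(F)(F)F` differs from compound 3 in one place: 3-(trifluoromethyl)phenyl in place of pyridin-2-yl on an amine nitrogen in a ring. Among the measured compounds shown here, no measured step touches this change directly, and the steps a step that the two limits leave unreadable from compound 1 to compound 2, a step that the two limits leave unreadable from compound 1 to compound 3 and a step that the two limits leave unreadable from compound 2 to compound 3 cannot be sized, since each runs between two limits. The step from compound 3 to compound 4 thus has no readable precedent. With every measured value at one limit, compound 4 is expected to give 100000 nM, within 30000 nM to 300000 nM. The expected step is a number no higher from compound 3 to compound 4 (the limit leaves the size open).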

Compound 4, concentration for total growth inhibition: 74100 nM
The estimate for compound 4 lay 1.3-fold (0.13 log units) above the measured number; low and high end bracket the measured number.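

In this assay, among the compounds shown here, 3-(trifluoromethyl)phenyl on the ring amine nitrogen gives the only value shown that is a number rather than a limit, which sets compound 4 apart from the others: the limit of > 100000 nM in this assay, at which 3 of the 4 values shown sit. The change reads as an at least 1.3-fold lower number from compound 3 to compound 4 (0.13 log units; that floor lies within the scatter), and as an at least 1.3-fold lower number from compound 2 to compound 4 (0.13 log units; that floor lies within the scatter). On these data alone, both are floors, so the true size of each step stays open, and the steps among the three limits cannot be read.

The compounds shown leave open whether the trifluoromethyl group or the all-carbon aromatic ring carries this difference. An unsubstituted phenyl at the same nitrogen, or a methoxy group in place of trifluoromethyl, would bear on that question.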